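Replacing 4-fluorophenyl with 4-cyanophenyl: working notes

The compounds below may be only part of what the source reports. "The series", "measured", "known", "first", "only" and "open" are said of these compounds alone.

Measured so far in a functional assay on OVCAR-8 cells (Homo sapiens); a higher number here means a weaker inhibitor of growth, a lower number a stronger inhibitor of growth:
compound 1 `O=S(=O)(/C=C/c1ccccc1)Cc1ccc(Nc2ncnc3ccccc23)cc1` (> 100000 nM) is a limit of the assay, not a number
compound 2 `O=S(=O)(/C=C/c1ccc(F)cc1)Cc1ccc(Nc2ncnc3ccccc23)cc1` (2000 nM) is a number

Going by the values given here, compound 2 holds the only actual number, and the sole other result is a limit.

Compound 3 `N#Cc1ccc(/C=C/S(=O)(=O)Cc2ccc(Nc3ncnc4ccccc34)cc2)cc1` is still unmeasured. It has cyano in place of fluoro on an aromatic carbon, para to a large group (cyano in place of fluoro on an aromatic carbon).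

Among the compounds with values here, only one measured step bears on this carbon, and it replaces hydrogen with fluoro (an at least 50-fold lower number from compound 1 to compound 2 (1.69 log units; beyond the scatter)). From the compounds shown here alone, that step is large and beyond the scatter, but one end of it is a limit, so its true size stays open. It says nothing direct about cyano. Compound 3 keeps a substituent at this carbon, so a return to the limit seen for compound 1 is not the expected outcome. The expected step (a 1.3-fold higher number from compound 2 to compound 3 (0.10 log units; within the scatter)) has no firm direction and may not exceed the scatter.

The estimate for compound 3 is 2500 nM (expected range 500 nM to 15000 nM).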

Compound 3, concentration for 50% growth inhibition: > 100000 nM
Compound 3: no number, only a limit; the forecaster's own chance of this, stated with the estimate: 15%; at least 40-fold (1.60 log units) between middle value and limit.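

In this assay, cyano in place of fluoro on this aromatic carbon gives an at least 50-fold higher number from compound 2 to compound 3 (1.69 log units; beyond the scatter), so having a substituent at this carbon is not enough to retain the growth inhibition seen for compound 2. Of the three groups shown at this carbon, only fluoro gives a number, while hydrogen in compound 1 and cyano in compound 3 each give a limit rather than a number. The true size of the step to compound 3 therefore stays open, and the step from compound 1 to compound 3 cannot be read: the limit of > 100000 nM in this assay, at which 2 of the 3 values shown sit.

From the compounds shown here alone, whether chloro, methoxy or an amine at this carbon would give a number like that of compound 2 or a limit like that of compound 3 remains open. With only one number in the series, the compounds shown cannot tell whether fluoro is unusual here or merely one of several tolerated groups.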